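A few compounds are considered here, and "the series" means these few. Any claim that something is new, unique, unknown or untested is made for them only; others in the source may bear on it.

Of the compounds shown here, two have been measured in a functional assay on HeLa cells (Homo sapiens) for cytotoxicity, read by MTT assay, with a stated time of 48 h; on this read-out higher numbers stand for weaker inhibition and lower numbers for stronger inhibition. Compound 1 `Cc1ccccc1Cn1cc(COc2ccc3c(=O)ccoc3c2)nn1` gives 15300 nM, the lower of the two numbers. Compound 2 `C#CCOc1ccc2c(=O)ccoc2c1` gives 64700 nM, a higher number than compound 1 by a gap beyond the scatter of repeated runs, so compound 1 is the stronger inhibitor of the pair. Within the data shown here, no single-point step between these two is worked out here; they stand simply as the two values at hand.

Compound 3 `O=c1ccoc2cc(OCc3cn(Cc4ccc(F)cc4)nn3)ccc12` has not yet been measured. It differs from compound 1 in one place: 4-fluorophenyl in place of 2-methylphenyl on a saturated chain carbon bound to an aromatic nitrogen. The group that leaves and the group that enters have the same count of heavy atoms, each a six-membered aromatic ring of carbon only, with no hydrogen-bond donors or acceptors, sitting on the saturated chain carbon bound to an aromatic nitrogen. Among the measured compounds shown here, no measured pair shows what such a swap does in this assay, so nothing points to a gain or a loss. The step is expected to be a 1.0-fold lower number from compound 1 to compound 3 (0.01 log units; within the scatter), which is to say none beyond the scatter. On this basis compound 3 is estimated to give about 15000 nM, within a likely range from 6000 nM to 40000 nM.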

Compound 3, half-maximal inhibitory concentration: 12000 nM
Beside the measured number, compound 3's estimate is 1.3-fold (0.10 log units) above it, and the stated range covers the measured number.
By their numbers in this assay, from the lowest: compounds 3 and 1 (each within the scatter of the next); then compound 2.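

Among these compounds, this is the first pair in this assay that differs in one place, and putting 4-fluorophenyl in place of 2-methylphenyl on a saturated chain carbon bound to an aromatic nitrogen gives a 1.3-fold lower number from compound 1 to compound 3 (0.11 log units; within the scatter), so the two compounds cannot be told apart on this read-out. At this place, then, one ring carrying a methyl group can be exchanged for one carrying a fluorine, with the same count of heavy atoms, without a shift that the assay can resolve, although this single step changes both the substituent and its place on the ring and cannot separate the two changes. No measurement at hand bears on the reason for this outcome.

The compounds shown leave open whether 4-methylphenyl or 2-fluorophenyl would also stay within the scatter, which would help to separate the effect of the substituent from that of its place on the ring. They also leave open what happens when the ring at this place gives way to a different kind of group, such as a longer saturated chain, an amine or a carboxylic acid.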